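A few compounds are considered here, and "the series" means these few. Any claim that something is new, unique, unknown or untested is made for them only; others in the source may bear on it.

Measured in an ADME assay on S9 fraction from liver (Rattus norvegicus) for metabolic stability, read by LC-MS, using NADPH, with a stated time of 30 min; a higher number here means that more of the compound is left, a lower number that less of the compound is left:
- compound 1 `CCCCCCCCc1ccc(OCC(=O)Cn2ncnn2)cc1`: < 5% (limit)
- compound 2 `CCCCCCCCc1ccc(OCC(=O)Cn2nnc(SC)n2)cc1`: < 5% (limit)
- compound 3 `CCCCCCCCc1ccc(OCC(=O)Cn2nnnc2SC)cc1`: 21%

Within the data shown here, compound 3 gives the only actual number so far, 21%. The rest of the series stands at the limit of < 5% in this assay, at which 2 of the 3 values shown sit, which is a limit and not a number.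

Compound 4 `CCCCCCCCc1ccc(OCC(=O)Cn2nnnc2-c2cccnc2)cc1` carries pyridin-3-yl in place of methylsulfanyl on an aromatic carbon.

Two readable steps bear on this change: a number at least 16 percentage points higher from compound 1 to compound 3 (beyond the scatter) and a number at least 16 percentage points higher from compound 2 to compound 3 (beyond the scatter). Both end in the group that is altered here, but neither replaces methylsulfanyl with another substituent. Among the measured compounds shown here, the only step that changes methylsulfanyl alone, a step that the two limits leave unreadable from compound 1 to compound 2, cannot be read. The data therefore give no direction for this change, and compound 3 at 21% remains the anchor.

The expected result is a number 1 percentage points lower from compound 3 to compound 4 (within the scatter), with no change beyond the scatter anticipated. For compound 4 the estimated value is 20%, with an expected range from 5% to 45%.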

Compound 4, percent of the compound remaining: 20%
Estimate against measurement, compound 4: no gap at the digits printed, within the range that was stated.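

In this assay, the aromatic carbon of the five-membered aromatic ring with 4 nitrogen takes pyridin-3-yl in place of methylsulfanyl with a number 1 percentage points lower from compound 3 to compound 4 (within the scatter). A six-membered aromatic ring with 1 hetero atom thus replaces a group with no ring, and the read-out shows no change beyond the scatter. This is the only readable step that changes the substituent on this carbon alone, since the earlier step on methylsulfanyl cannot be read, and two values in the series remain a limit rather than a number: the limit of < 5% in this assay, at which 2 of the 4 values shown sit.

The compounds shown leave open how an amine or a carboxylic acid on this carbon would read in this assay. Also open, on these data alone, is whether a shorter chain on the shared core would shift the read-out beyond the scatter.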